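The compounds below may be only part of what the source reports. "The series", "measured", "known", "first", "only" and "open" are said of these compounds alone.

Measured compounds:
- compound 1 `CNC(=O)c1cc(Oc2ccc(NC(=O)c3cc4cccnc4n(-c4ccc(C(F)(F)F)cc4Cl)c3=O)cc2)ccn1`: in a functional assay on A549 cells (Homo sapiens) for antiproliferative activity, read by MTT assay, with a stated time of 72 h (on this read-out lower numbers stand for stronger inhibition and higher numbers for weaker inhibition), compound 1 gives 2090 nM
- compound 2 `CCNC(=O)c1cc(Oc2ccc(NC(=O)c3cc4cccnc4n(-c4ccccc4)c3=O)cc2)ccn1`: in this assay compound 2 gives 160 nM

Of these two numbers, compound 2 has the lower one, and the gap to compound 1 lies beyond the scatter. Compound 1 differs from compound 2 in more than one place, so no single change can be held responsible for that gap.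

Compound 3 `CCNC(=O)c1cc(Oc2ccc(NC(=O)c3cc4cccnc4n(-c4ccc(Br)cc4F)c3=O)cc2)ccn1` has not yet been measured. It differs from compound 2 in one place: 4-bromo-2-fluorophenyl in place of phenyl on an aromatic nitrogen.

For the measured compounds named here, no measured pair shows this change on its own. Going by the values given here, the only hint is that compound 1, which carries a substituted ring in the same place, gives the weaker number, but that compound also carries a different amide, so the hint is loose. A step in this assay toward a somewhat higher number is expected for compound 3, roughly a 2.5-fold higher number from compound 2 to compound 3 (0.40 log units; beyond the scatter), though a step within the scatter would not surprise. Compound 3 is expected to give about 400 nM, with a range from 120 nM to 1500 nM.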

Compound 3, half-maximal inhibitory concentration: 1820 nM
Compound 3: the middle estimate sits 4.6-fold (0.66 log units) below what was measured, outside the stated range (above it).
By their numbers in this assay, from the lowest: compound 2; then compounds 3 and 1 (each within the scatter of the next).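

In this assay, putting 4-bromo-2-fluorophenyl in place of phenyl on the aromatic nitrogen gives an 11-fold higher number from compound 2 to compound 3 (1.06 log units; beyond the scatter), a large step in the direction of weaker inhibition. For the compounds shown here, this is the first pair that differs in this one place only, so it replaces the loose hint from compound 1 with a direct reading: what sits on this ring strongly affects the number, and here the plain phenyl of compound 2 is clearly the better of the two groups. Nothing measured here explains why the number rises, whether in the cells or in any property of the compounds.

The change adds a bromine and a fluorine together, so the compounds shown cannot tell whether one of them accounts for most of the step, which a ring carrying only the fluorine or only the bromine would help to settle. From the compounds shown here alone, it also remains open how this position would respond to other groups, such as a methoxy group or an amine on the phenyl ring, or a simple methyl on the nitrogen in place of the ring.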